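The source may report more compounds than this note shows. Statements on the series, on what has been measured and on what is new or still open speak of the compounds shown alone.

Measured compounds:

compound 1 `CCN(CC)CN1C(=O)/C(=N\c2nc3ccc(C)cc3s2)c2c(Br)cccc21`, 28700 nM
compound 2 `O=C1C(=O)N(CN2CCCCC2)c2cccc(Cl)c21`, 26500 nM
compound 3 `Cc1ccc2nc(/N=C3\C(=O)N(CN4CCCCC4)c4cccc(Br)c43)sc2c1`, 38300 nM

All three were tested in a functional assay on MDA-MB-231 cells (Homo sapiens) for cytotoxicity, read by sulforhodamine B assay, with a stated time of 48 h; a lower number here means a stronger inhibitor of growth, a higher number a weaker inhibitor of growth. Compound 1 and compound 3 share a core and differ only in one group: diethylamino in place of piperidin-1-yl on a saturated chain carbon bound to an amide-type nitrogen in a ring. That exchange gave a 1.3-fold lower number from compound 3 to compound 1 (0.13 log units; within the scatter), so the two values lie within the scatter of each other. Compound 2 carries a different core; how the two cores differ is not broken down here. In this assay compound 2 gives 26500 nM, and the values of compound 1 and compound 3 stand within the scatter of it.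

Compound 4 `CCN(CC)CN1C(=O)C(=O)c2c(Cl)cccc21` has not yet been measured. It is related to compound 2 by the same change that relates compound 3 to compound 1: diethylamino in place of piperidin-1-yl on a saturated chain carbon bound to an amide-type nitrogen in a ring. Since the step from compound 3 to compound 1 was a 1.3-fold lower number from compound 3 to compound 1 (0.13 log units; within the scatter), the same change on the core of compound 2 is expected to give a similar, small step, a 1.2-fold lower number from compound 2 to compound 4 (0.08 log units; within the scatter). Compound 4 is therefore estimated at 22000 nM, with a range from 10000 nM to 50000 nM.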

Compound 4, concentration for 50% growth inhibition: 44500 nM
For compound 4 the middle estimate is 2.0-fold (0.31 log units) below the measured one; measured number inside the range.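

In this assay, diethylamino in place of piperidin-1-yl gives a 1.7-fold higher number from compound 2 to compound 4 (0.23 log units; within the scatter), so this step, like the earlier one, stays within the scatter. The two steps are printed in opposite directions, but the gap between them gives no sign that the outcome of the exchange depends on the core: the same change on two cores in this assay, a 1.3-fold lower number (0.13 log units; within the scatter) from compound 3 to compound 1 and a 1.7-fold higher number (0.23 log units; within the scatter) from compound 2 to compound 4, 2.2-fold (0.35 log units) apart, within the scatter of two such steps. The two pairs show that the exchange produced no step beyond the scatter on either core, but they do not show that its effect is identical on both, and they say nothing about any other core or any other assay.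

Every compound shown carries either piperidin-1-yl or diethylamino on the saturated chain carbon, so the effect of other amines at that place, such as morpholin-4-yl or dimethylamino, remains open. Also open, from the compounds shown here alone, is the effect of chlorine against bromine on the ring with the amine and the rest of the core held fixed.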